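Swapping a Cyclobutyl Amide for a Thiazolyl Amide

The source may report more compounds than this note shows. Statements on the series, on what has been measured and on what is new or still open speak of the compounds shown alone.

Measured so far:
compound 1, `CCC(=O)N1CCc2nc(C#Cc3ccccc3)sc2C1`, 38 nM
compound 2, `O=C(C1CC(F)C1)N1CCc2nc(C#Cc3ccccc3)sc2C1`, > 10000 nM
compound 3, `COC1CC(C(=O)N2CCc3nc(C#Cc4ccccc4)sc3C2)C1`, > 10000 nM

Three compounds share one core and differ only in the group attached to the carbonyl carbon of the amide. In an assay on HEK293 cells for negative allosteric modulation of metabotropic glutamate receptor 5 (Homo sapiens), read by FLIPR, with a stated time of 1 h (a lower number here means a stronger inhibitor, a higher number a weaker inhibitor), compound 1 gives 38 nM. For compound 2 the assay reports only a limit, > 10000 nM. For compound 3 the result is likewise only a limit, > 10000 nM. Compound 3 thus sits at the weak edge of the numbers shown, at the limit of > 10000 nM in this assay, at which 2 of the 3 values shown sit, and the comparison with compound 2 is a step that the two limits leave unreadable from compound 2 to compound 3.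

Compound 4, `Cc1nc(C(=O)N2CCc3nc(C#Cc4ccccc4)sc3C2)cs1`, has not yet been measured. The change is 2-methyl-1,3-thiazol-4-yl in place of 3-methoxycyclobutyl on a carbonyl carbon.

Within the data shown here, two measured steps bear on this position: an at least 260-fold higher number from compound 1 to compound 3 (2.42 log units; beyond the scatter) and an at least 260-fold higher number from compound 1 to compound 2 (2.42 log units; beyond the scatter), both large losses when a cyclobutyl group replaces ethyl. Neither step covers an aromatic group at this position, so the direction is uncertain, and the starting point is only a limit. Compound 4 is expected to give 2500 nM, within 300 nM to 10000 nM, which would mean an estimated at least 4.0-fold lower number from compound 3 to compound 4 (0.60 log units; beyond the scatter).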

Compound 4, half-maximal inhibitory concentration: > 10000 nM
Compound 4 was reported as a limit; the forecaster's own chance of this, stated with the estimate: 40%; at least 4.0-fold (0.60 log units) between middle value and limit.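

Replacing ethyl with 2-methyl-1,3-thiazol-4-yl on the carbonyl carbon gives an at least 260-fold higher number from compound 1 to compound 4 (2.42 log units; beyond the scatter), so the large loss seen with the two cyclobutyl groups is not confined to a four-membered non-aromatic ring. The result for compound 4 is only a limit, and the steps to it from compound 2 and from compound 3 cannot be read, so these three amides cannot be ranked against one another. Compound 1 is now the only compound shown with a measured number, and the other three sit together: the limit of > 10000 nM in this assay, at which 3 of the 4 values shown sit.

The compounds shown leave open how much larger than ethyl this group can become before the activity is lost: a propyl chain, an isopropyl group or a cyclopropyl ring would each be a smaller change from compound 1. They also leave open whether the ring itself or its substituent matters, which an unsubstituted cyclobutyl ring or a thiazole without its methyl group could begin to separate.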